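A few compounds are considered here, and "the series" means these few. Any claim that something is new, unique, unknown or untested is made for them only; others in the source may bear on it.

Measured so far:
Compound 1 `O=C(NNc1ccccc1Cl)c1cccc(NS(=O)(=O)c2cnc(O)nc2O)c1`: 2270 nM in a functional assay on SGC-7901 cells (Homo sapiens) for antiproliferative activity, read by MTT assay, with a stated time of 24 h; a lower number here means a stronger inhibitor, a higher number a weaker inhibitor.
Compound 2 `O=C(NNC(=O)c1ccccc1F)c1ccc(NS(=O)(=O)c2cnc(O)nc2O)cc1`: > 20000 nM, a limit of this assay rather than a number.

Going by the values given here, compound 1 holds the only measured number in the set; the other value is a limit, (the limit of > 20000 nM in this assay, at which 1 of the 2 values shown sits). Compound 3 `O=C(NNC(=O)c1cccc(NS(=O)(=O)c2cnc(O)nc2O)c1)c1ccc(F)cc1` is not yet measured. It differs from compound 1 by (4-fluorophenyl)carbonyl in place of 2-chlorophenyl on an amine nitrogen. Among the compounds with values here, no step between measured compounds is available, so the size of this change is open; the limit reached by compound 2 points toward weaker inhibition when a carbonyl sits on that nitrogen. Compound 3 is expected to come out weaker, well beyond the scatter, a 5.3-fold higher number from compound 1 to compound 3 (0.72 log units; beyond the scatter), at an estimated 12000 nM within 3000 nM to 40000 nM.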

Compound 3, half-maximal inhibitory concentration: > 20000 nM
Compound 3: a limit, no number (the forecaster's own chance of this, stated with the estimate: 40%); middle value at least 1.6-fold (0.22 log units) away from the limit.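

In this assay, going by these compounds alone, compound 3 gives > 20000 nM, a limit of the assay and not a number. (4-Fluorophenyl)carbonyl in place of 2-chlorophenyl on the amine nitrogen gives an at least 8.8-fold higher number from compound 1 to compound 3 (0.94 log units; beyond the scatter), the first readable step at this position, and its full size stays unknown. The same limit now recurs in the series: the limit of > 20000 nM in this assay, at which 2 of the 3 values shown sit.

The compounds shown do not separate the entry of the carbonyl from the change of ring substituent. A 4-fluorophenyl or a (2-chlorophenyl)carbonyl on that nitrogen would bear on this question.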